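Chloro for methyl on the core: stability notes

The compounds below may be only part of what the source reports. "The series", "measured", "known", "first", "only" and "open" are said of these compounds alone.

Measured so far:
- compound 1, `Cc1nc(N[C@@H]2C[C@H]3CC[C@@H]2C3)c2cc(-c3ccc(Cl)c(Cl)c3)ccc2n1`: in an ADME assay (Rattus norvegicus) for metabolic stability (a higher number here means that more of the compound is left, a lower number that less of the compound is left), compound 1 gives 63%
- compound 2, `Cc1nc(N[C@@H]2C[C@H]3CC[C@@H]2C3)c2cc(-c3cccc(C(F)(F)F)c3)ccc2n1`: in this assay compound 2 gives 41%
- compound 3, `Clc1nc(N[C@@H]2C[C@H]3CC[C@@H]2C3)c2cc(-c3ccc(Cl)c(Cl)c3)ccc2n1`: in this assay compound 3 gives 59%

Compound 2 shows the lowest of the three numbers; its distance to compound 3 and to compound 1 is beyond the scatter in both cases. The change chloro in place of methyl on an aromatic carbon gave a number 4 percentage points lower from compound 1 to compound 3 (within the scatter). How the cores of compound 1 and compound 2 differ is not broken down here.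

Compound 4, `FC(F)(F)c1cccc(-c2ccc3nc(Cl)nc(N[C@@H]4C[C@H]5CC[C@@H]4C5)c3c2)c1`, is not yet measured. It differs from compound 2 by chloro in place of methyl on an aromatic carbon, the same change as from compound 1 to compound 3, at the same place. Within the data shown here, on the single measured precedent, a number 4 percentage points lower from compound 1 to compound 3 (within the scatter), compound 4 is expected to sit close to compound 2, with an estimated a number 4 percentage points lower from compound 2 to compound 4 (within the scatter); this rests on one pair only. Compound 4 is therefore estimated at 37%, expected between 22% and 52%.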

Compound 4, percent of the compound remaining: 67%
Estimate against measurement, compound 4: 30 percentage points below, and the stated range ends below it.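

In this assay, chloro in place of methyl on an aromatic carbon gave a number 26 percentage points higher from compound 2 to compound 4 (beyond the scatter). This step differs from the earlier one, so the effect of the change did not carry over unchanged from one core to the other: the same change on two cores in this assay, a number 4 percentage points lower (within the scatter) from compound 1 to compound 3 and a number 26 percentage points higher (beyond the scatter) from compound 2 to compound 4, 30 percentage points apart, beyond the scatter of two such steps. The two pairs show that the step need not transfer between cores in this series, but they do not show which difference between the cores goes with the gap, or what a further core would give.

Open, as far as these compounds go, is how an amine or a nitrile at this place, between two ring nitrogen atoms, would compare with methyl and chloro on either core. Among these compounds, each core also offers only one pair for this change, so how well either step repeats remains open.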